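The compounds below may be only part of what the source reports. "The series", "measured", "known", "first", "only" and "open" are said of these compounds alone.

In an ADME assay on RAW264.7 cells (Mus musculus) for cytotoxicity, read by MTT assay, with a stated time of 24 h, tested at 2.5 ug/mL (on this read-out lower numbers stand for a stronger effect and higher numbers for a weaker effect at the one concentration tested), the three measured compounds gave these numbers:

Compound 1, `COc1ccc(/C=C/C(=O)c2ccc(OC)c(OC)c2)cc1OC`: 91.9%
Compound 2, `COc1ccc(C(=O)CCc2ccc(OC)cc2OC)c(O)c1`: 96.2%
Compound 3, `COc1ccc(CCC(=O)c2ccc(OC)cc2O)cc1`: 94.5%

All three numbers sit close together. Within the data shown here, compound 2 has the largest of the three, yet the gap to compound 3 is a number 1.7 percentage points lower from compound 2 to compound 3 (within the scatter), and the value of compound 1 differs from that of compound 2 by less than the usual scatter of this measurement, so no compound can be told apart from another on these figures.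

The compound not yet measured is compound 4, `COc1ccc(C(=O)CCc2ccc(OC)c(OC)c2OC)c(O)c1`. Set against compound 2 the change is methoxy in place of hydrogen on an aromatic carbon.

Among the measured compounds shown here, one measured step bears on this: from compound 2 to compound 3 the same kind of group was removed at an aromatic carbon, and that step was a number 1.7 percentage points lower from compound 2 to compound 3 (within the scatter). Adding a methoxy in compound 4 is the reverse kind of change, and nothing among the three compounds hints that such a swap moves the read-out. Compound 4 is therefore expected to come out close to compound 2, a shift of a number 1.2 percentage points lower from compound 2 to compound 4 (within the scatter), meaning no step beyond the scatter. The estimate for compound 4 in this assay is 95%, within a range from 88% to 100%.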

Compound 4, a percentage reported as activity, at one concentration (the size of the read-out at that concentration, not a potency): 94.4%
Beside the measured number, compound 4's estimate is 0.6 percentage points above it; low and high end bracket the measured number.
By their numbers in this assay, from the lowest: compounds 1, 4, 3 and 2 (each within the scatter of the next).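

In this assay the methoxy that enters compound 4 sits on an aromatic carbon ortho to two methoxy groups and meta to a large group, and this change gives a number 1.8 percentage points lower from compound 2 to compound 4 (within the scatter) with no step beyond the scatter. The earlier compounds shown here showed a methoxy change at only one other place, a number 1.7 percentage points lower from compound 2 to compound 3 (within the scatter) and that step also stayed within the scatter, so the read-out now shows no separable step for a methoxy change at either of two different places on compounds that share a core. Nothing available explains why the read-out stays put at this position.

The compounds shown leave open whether a different group on this same carbon, such as an amine or a carboxylic acid, would move the read-out beyond the scatter. With a single tested concentration and only methoxy and hydrogen compared here, they also cannot tell whether a methoxy at this position would make any difference at a higher concentration.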